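A few compounds are considered here, and "the series" means these few. Any claim that something is new, unique, unknown or untested is made for them only; others in the source may bear on it.

Compound 1 `CCOC(=O)c1c(C)[nH]c(=O)c(C#N)c1-c1ccco1` and compound 2 `CCOC(=O)c1c(C)[nH]c(=O)c(C#N)c1-c1ccc([N+](=O)[O-])cc1` share one core and differ only in the group attached to it. In a functional assay on aorta (Rattus norvegicus) for inhibition (a higher number here means a larger maximal response, a lower number a smaller maximal response), compound 1 reaches 93%. In this assay compound 2 reaches 95%, numerically the larger of the two numbers on record, but the gap to compound 1 lies within the scatter, so the two cannot be told apart. Compound 3 `CCOC(=O)c1c(C)[nH]c(=O)c(C#N)c1-c1ccc([N+](=O)[O-])cc1[N+](=O)[O-]` has not yet been measured in this assay. It differs from compound 2 in one place: nitro in place of hydrogen on an aromatic carbon. Going by the values given here, no step between measured compounds is available to guide the reading, so the expectation rests on the two values alone. Because compound 2 gives 95% and compound 1 stands level with it, the expected step is a small one with no clear direction, within the scatter, namely a number 3 percentage points lower from compound 2 to compound 3 (within the scatter). For compound 3 the estimated maximal response in this assay is 92%, with a range from 80% to 100%.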

Compound 3, largest response reached (reported as efficacy), in percent of the reference or control that the assay uses: 99%
Compound 3: the middle estimate sits 7 percentage points below what was measured, within the range that was stated.
By their numbers in this assay, from the lowest: compounds 1, 2 and 3 (each within the scatter of the next).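

In this assay, nitro in place of hydrogen on an aromatic carbon, ortho to a large group and meta to the nitro group already present, gives a number 4 percentage points higher from compound 2 to compound 3 (within the scatter), so the two compounds cannot be told apart. The earlier pair, which differ in the whole group attached to the shared core, could not show this: the six-membered aromatic ring of compound 2 can carry a second nitro group at this place, with its 3 heavy atoms, without a step that stands out from the scatter. No measurement on hand bears on why the maximal response stays level across this change.

The compounds shown leave open whether an amine, a methoxy group or a carboxylic acid at this same place would also stay level with compound 2, or would give a step beyond the scatter. As far as these compounds go, they also leave open how a nitro group at this place would read on a ring without the nitro group of compound 2, so its contribution alone remains unknown.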